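Removing One Methoxy Group from Compound 1

The source may report more compounds than this note shows. Statements on the series, on what has been measured and on what is new or still open speak of the compounds shown alone.

Compound 1 `COc1ccc(-c2c(OCC(=O)Nc3cccc4ccccc34)oc3ccccc3c2=O)cc1OC`: > 100000 nM (a limit)
Compound 2 `O=C(COc1c(-c2ccccc2Cl)oc2ccccc2c1=O)Nc1ccc2c(c1)COC2=O`: 67600 nM

In an ADME assay on MDCK-II cells (Canis lupus familiaris) for inhibition, read by MTT assay, with a stated time of 72 h (a lower number here means a stronger inhibitor of growth, a higher number a weaker inhibitor of growth), compound 1 gives > 100000 nM, which is a limit of the assay and not a number. Compound 1 therefore has no exact value, only (the limit of > 100000 nM in this assay, at which 1 of the 2 values shown sits). Compound 2 gives 67600 nM in this assay. Compound 3 `COc1ccc(-c2c(OCC(=O)Nc3cccc4ccccc34)oc3ccccc3c2=O)cc1` has not yet been measured. It differs from compound 1 by hydrogen in place of methoxy on an aromatic carbon, so that 3,4-dimethoxyphenyl becomes 4-methoxyphenyl. Within the data shown here, no measured step shows what this change does here. The step of a number no higher from compound 1 to compound 3 (the limit leaves the size open) is therefore expected to stay within the scatter, with no direction expected. For compound 3 the estimated value is 100000 nM, with an expected range from 40000 nM to 200000 nM.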

Compound 3, concentration for 50% growth inhibition: > 100000 nM
Compound 3 was reported as a limit; the forecaster's own chance of this, stated with the estimate: 60%; the middle value lies on the limit itself.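

No step from compound 1 to compound 3 can be read in this assay, because both results are limits and not numbers: the limit of > 100000 nM in this assay, at which 2 of the 3 values shown sit.

Going by these compounds, whether hydrogen in place of methoxy on an aromatic carbon changes growth inhibition at all, and in which direction, remains open.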